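This account rests on a few compounds, and the source may have more. Where it says the series, first, only, none or still open, it means among the compounds named here.

Measured in a functional assay on HT-29 cells (Homo sapiens) for antiproliferative activity, read by sulforhodamine B assay, with a stated time of 48 h; on this read-out lower numbers stand for stronger inhibition and higher numbers for weaker inhibition:
- Compound 1 (`Cc1ccc(NS(=O)(=O)c2ccc(N3CCNC3=O)cc2)cc1`) gives 480 nM
- Compound 2 (`CCCCCCCc1ccc(NS(=O)(=O)c2ccc(N3CCNC3=O)cc2)cc1`) gives > 1000 nM (a limit of the assay, not a number)
- Compound 3 (`O=C1NCCN1c1ccc(S(=O)(=O)Nc2ccc(Cl)cc2)cc1`) gives 220 nM

Of the two actual numbers, compound 3 holds the lower, and compound 1 is its nearest neighbour. The gap between them is a 2.2-fold lower number from compound 1 to compound 3 (0.34 log units; beyond the scatter).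

Compound 4 (`CC(C)Cc1ccc(NS(=O)(=O)c2ccc(N3CCNC3=O)cc2)cc1`) has not yet been measured. It carries isobutyl in place of chloro on an aromatic carbon.

Going by the values given here, three measured steps bear on this change. Chloro in place of methyl gave a 2.2-fold lower number from compound 1 to compound 3 (0.34 log units; beyond the scatter), and chloro in place of heptyl gave an at least 4.5-fold lower number from compound 2 to compound 3 (0.65 log units; beyond the scatter). Among these three compounds, then, both alkyl-bearing ones sit higher than the chloro compound. Hexyl added to the methyl group gave an at least 2.0-fold higher number from compound 1 to compound 2 (0.31 log units; beyond the scatter), a step known only from one side. Isobutyl is an alkyl group that falls between methyl and heptyl in size, so removing chloro in its favour should undo a step of similar, modest size, and a result at the limit of the assay remains possible. The expected change is a 2.7-fold higher number from compound 3 to compound 4 (0.44 log units; beyond the scatter), towards weaker inhibition. For compound 4 the estimated value is 600 nM, with an expected range from 250 nM to 1400 nM.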

Compound 4, half-maximal inhibitory concentration: > 1000 nM
Compound 4: a limit, no number; the forecaster's own chance of this, stated with the estimate: 25%; middle value at least 1.6-fold (0.22 log units) away from the limit.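

In this assay, isobutyl in place of chloro on an aromatic carbon, para to a large group, gives an at least 4.5-fold higher number from compound 3 to compound 4 (0.65 log units; beyond the scatter), so at this position an alkyl group far shorter than the heptyl of compound 2 is already enough to weaken inhibition beyond the scatter. Measured against methyl, the larger isobutyl group gives an at least 2.0-fold higher number from compound 1 to compound 4 (0.31 log units; beyond the scatter), which shows that the rise seen with the long straight chain also appears with a short branched one. The value of compound 4 is a limit of the assay and not a number, as is that of compound 2, so the step between these two cannot be read and the two groups cannot be ranked against each other: the limit of > 1000 nM in this assay, at which 2 of the 4 values shown sit.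

On these data alone, it remains open whether an ethyl or propyl group would stay close to the methyl of compound 1 or would already reach the limit, and how far the true values of compound 2 and compound 4 lie beyond it. Also open, as far as these compounds go, is whether a fluoro or bromo group, or an amine, in place of the chloro of compound 3 would keep its stronger inhibition.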